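From 3-methoxyphenyl to 4-methoxyphenyl on the shared core

The source may hold more compounds than are shown below. What is called first, only, known or untested is meant among the compounds shown, and "the series" means these compounds.

In a functional assay on HL-60 cells (Homo sapiens) for cytotoxicity, read by WST assay, with a stated time of 48 h (on this read-out higher numbers stand for weaker inhibition and lower numbers for stronger inhibition), compound 3 `COc1cccc(/C=C/C[C@H]2C[C@@H]([C@@H](O)c3ccccc3)CO[C@@H]2c2ccccc2)c1` gives 9620 nM, level with compound 1 `Oc1ccccc1/C=C/C[C@H]1C[C@@H]([C@@H](O)c2ccccc2)CO[C@@H]1c1ccccc1` at 10800 nM, while compound 2 `O[C@@H](c1ccccc1)[C@H]1CO[C@H](c2ccccc2)[C@@H](C/C=C/c2ccccn2)C1` reads 36400 nM. Compound 4 `COc1ccc(/C=C/C[C@H]2C[C@@H]([C@@H](O)c3ccccc3)CO[C@@H]2c2ccccc2)cc1` differs from compound 3 at one place: 4-methoxyphenyl in place of 3-methoxyphenyl on a double-bonded chain carbon bound to a double-bonded chain carbon. For the measured compounds named here, no measured step isolates this change. The nearest evidence is a 1.1-fold lower number from compound 1 to compound 3 (0.05 log units; within the scatter), which exchanged 2-hydroxyphenyl for 3-methoxyphenyl. Only the two steps involving pyridin-2-yl were larger, namely a 3.4-fold higher number from compound 1 to compound 2 (0.53 log units; beyond the scatter) and a 3.8-fold lower number from compound 2 to compound 3 (0.58 log units; beyond the scatter), and both were modest. Since compound 4 carries no pyridin-2-yl, no shift beyond the scatter is expected in this assay. The expected step is a 1.0-fold higher number from compound 3 to compound 4 (0.02 log units; within the scatter). Compound 4 is estimated at 10000 nM, with an expected range of 4500 nM to 24000 nM.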

Compound 4, half-maximal inhibitory concentration: 9010 nM
Estimate against measurement, compound 4: 1.1-fold (0.05 log units) above; the range from low to high includes it.
By their numbers in this assay, from the lowest: compounds 4, 3 and 1 (each within the scatter of the next); then compound 2.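

In this assay the exchange of 3-methoxyphenyl for 4-methoxyphenyl gives a 1.1-fold lower number from compound 3 to compound 4 (0.03 log units; within the scatter), the first direct read on moving the methoxy group within this aryl substituent. For the compounds shown here, the step from 2-hydroxyphenyl gives a 1.2-fold lower number from compound 1 to compound 4 (0.08 log units; within the scatter), while the step from pyridin-2-yl gives a 4.0-fold lower number from compound 2 to compound 4 (0.61 log units; beyond the scatter), so pyridin-2-yl remains the only group here set apart from the others. No evidence is available to explain these results. Going by these compounds, whether an amine or a carboxylic acid in place of the methoxy group, or a longer chain in place of 2-(4-methoxyphenyl)ethenyl, would shift the number beyond the scatter remains open.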